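Compound 3 to compound 4: a change made at the limit

The compounds below may be only part of what the source reports. "The series", "measured", "known", "first", "only" and "open" are said of these compounds alone.

The measured compounds:
Compound 1, `Cc1cc(C)cc(C(=O)N(CCCCCC(=O)Nc2ccccc2N)CC(=O)NC2CCCCC2)c1`, gives in an assay on Sf9 cells for inhibition of protein deacetylase HDAC6 (Homo sapiens), read by fluorescence, with a stated time of 90 min (a lower number here means a stronger inhibitor, a higher number a weaker inhibitor), only the limit > 10000 nM.
Compound 2, `CN(C)c1ccc(C(=O)N(CC(=O)NCc2ccccc2)Cc2ccc(C(=O)Nc3cc(-c4ccccc4)ccc3N)cc2)cc1`, gives in this assay only the limit > 10000 nM.
Compound 3, `CN(C)c1ccc(C(=O)N(CC(=O)NCc2ccccc2)Cc2ccc(C(=O)Nc3ccccc3N)cc2)cc1`, gives in this assay only the limit > 10000 nM.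

Compound 3 therefore stands nowhere in particular on the scale: its value is a limit, and so are the two other values shown, all three sitting at the limit of > 10000 nM in this assay, at which 3 of the 3 values shown sit. Among the compounds with values here, the one step between two measured compounds that differ in a single place, a step that the two limits leave unreadable from compound 2 to compound 3, is left unreadable by the two limits, and says nothing about size or direction.

Compound 4, `Cc1cc(C)cc(C(=O)N(CC(=O)NCc2ccccc2)Cc2ccc(C(=O)Nc3ccccc3N)cc2)c1`, differs from compound 3 in one place: 3,5-dimethylphenyl in place of 4-(dimethylamino)phenyl on a carbonyl carbon. Within the data shown here, no measured step bears on this exchange at the carbonyl carbon. Compound 1 carries the 3,5-dimethylphenyl group and compound 3 the 4-(dimethylamino)phenyl group, and both sit at the limit, so their comparison is not readable either. There is thus no ground to expect a readable step in this assay in either direction, and the expected step that the limit leaves unreadable from compound 3 to compound 4 is one at the limit. Compound 4 is estimated at 15000 nM, within 5000 nM to 50000 nM, most likely reported as a limit again.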

Compound 4, half-maximal inhibitory concentration: > 10000 nM
Compound 4 ended at the assay's limit (the forecaster's own chance of this, stated with the estimate: 85%); the middle value does not contradict the limit.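

In this assay compound 4 gives > 10000 nM, a limit and not a number. The step from compound 3 to compound 4 therefore cannot be read, and every value shown sits at one limit: the limit of > 10000 nM in this assay, at which 4 of the 4 values shown sit. The compounds shown leave open how large the exchange on the carbonyl carbon is, and in which direction it goes.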